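A few compounds are considered here, and "the series" means these few. Any claim that something is new, unique, unknown or untested is made for them only; others in the source may bear on it.

Measured compounds in a functional assay on VCaP cells (Homo sapiens) for antiproliferative activity, read by propidium iodide staining, with a stated time of 96 h; on this read-out lower numbers stand for stronger inhibition and higher numbers for weaker inhibition:
compound 1, `CC(O)(CSc1ccc(C(F)(F)F)cc1)C(=O)Nc1ccc(S(F)(F)(F)(F)F)cc1`, gives 24800 nM
compound 2, `CC(O)(CSc1cccc(C(F)(F)F)c1)C(=O)Nc1ccc(S(F)(F)(F)(F)F)cc1`, gives 18800 nM
compound 3, `CC(O)(CSc1ccc(OC(F)(F)F)cc1)C(=O)Nc1ccc(S(F)(F)(F)(F)F)cc1`, gives 16000 nM

All three numbers lie within the scatter of one another, so none of the three is set apart. Compound 1 and compound 3 differ by trifluoromethoxy in place of trifluoromethyl on an aromatic carbon, and this gave a 1.6-fold lower number from compound 1 to compound 3 (0.19 log units; within the scatter). The cores of compound 1 and compound 2 differ by 3-(trifluoromethyl)phenyl in place of 4-(trifluoromethyl)phenyl on a sulfur, which gave a 1.3-fold lower number from compound 1 to compound 2 (0.12 log units; within the scatter).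

Compound 4, `CC(O)(CSc1cccc(OC(F)(F)F)c1)C(=O)Nc1ccc(S(F)(F)(F)(F)F)cc1`, is not yet measured in this assay. It differs from compound 2 by trifluoromethoxy in place of trifluoromethyl on an aromatic carbon. This is the same kind of change as that from compound 1 to compound 3, but the place is not the same word for word: in compound 1 the group stands para to a large group, in compound 2 it stands meta to a large group.

The step from compound 2 to compound 4 is expected to be a 1.3-fold lower number from compound 2 to compound 4 (0.13 log units; within the scatter), close in size to a 1.6-fold lower number from compound 1 to compound 3 (0.19 log units; within the scatter), an expectation resting on compound 1 and compound 3 alone. That change has been measured only once here, so the range is kept wide. Compound 4 is estimated at 14000 nM, between 7000 nM and 28000 nM.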

Compound 4, half-maximal inhibitory concentration: 13800 nM
Beside the measured number, compound 4's estimate is 1.0-fold (0.01 log units) above it; low and high end bracket the measured number.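

In this assay, trifluoromethoxy in place of trifluoromethyl on an aromatic carbon gives a 1.4-fold lower number from compound 2 to compound 4 (0.13 log units; within the scatter). Set beside the earlier step, the change carries from one core to the other with no difference that can be told apart: the same change on two cores in this assay, a 1.6-fold lower number (0.19 log units; within the scatter) from compound 1 to compound 3 and a 1.4-fold lower number (0.13 log units; within the scatter) from compound 2 to compound 4, 1.1-fold (0.06 log units) apart, within the scatter of two such steps. For the compounds shown here, this shows only that two small steps agree; each lies within the scatter, so it does not show that the change truly lowers the number on either core, and two cores are too few to support a rule for the series.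

The compounds shown leave open whether a group other than trifluoromethyl or trifluoromethoxy on this aromatic ring, such as a nitrile, an amine or a carboxylic acid, would give a step beyond the scatter. Going by these compounds, the effect of a sulfonyl in place of the sulfur, or of a longer chain in place of the methyl on the carbon bearing the hydroxyl, is equally open.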